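From 4-fluorophenyl to 4-methoxy-2-nitrophenyl

The source may report more compounds than this note shows. Statements on the series, on what has been measured and on what is new or still open speak of the compounds shown alone.

In a functional assay for inhibition, with Homo sapiens as the target (a higher number here means weaker binding, a lower number tighter binding), compound 1 (`O=C(O)CC/C=C\CC1COC(c2ccc(Cl)cc2Cl)OC1c1cccnc1`) gives 891 nM and compound 2 (`CC(C)(Oc1ccc(F)cc1)C1OCC(C/C=C\CCC(=O)O)C(c2cccnc2)O1`) gives 120 nM as the lower of the two numbers. Compound 2 therefore shows the tighter binding, and the gap between the two lies beyond the scatter. Compound 3 (`COc1ccc(OC(C)(C)C2OCC(C/C=C\CCC(=O)O)C(c3cccnc3)O2)c([N+](=O)[O-])c1`) keeps the rest of compound 2 and changes one group: 4-methoxy-2-nitrophenyl in place of 4-fluorophenyl on an oxygen on a saturated carbon. Both groups hold one six-membered aromatic ring of carbon only, while the entering group also brings hydrogen-bond acceptors. Going by the values given here, no two measured compounds differ in one place only, so nothing yet shows what such a swap does. In this assay the expected outcome is no change beyond the scatter, with an estimated 1.2-fold lower number from compound 2 to compound 3 (0.08 log units; within the scatter) as the working figure. Compound 3 is expected near 100 nM with an estimated range from 30 nM to 350 nM as the likely span.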

Compound 3, dissociation constant: 6.17 nM
The estimate for compound 3 lay 16-fold (1.21 log units) above the measured number; the whole stated range lies above it.
By their numbers in this assay, from the lowest: compound 3; then compound 2; then compound 1.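

Putting 4-methoxy-2-nitrophenyl in place of 4-fluorophenyl on an oxygen on a saturated carbon gives, in this assay, a 19-fold lower number from compound 2 to compound 3 (1.29 log units; beyond the scatter). Going by these compounds alone, this is the first comparison here in which only one place changes, and it shows that this position responds strongly to what the aromatic ring carries, since the ring itself stays a six-membered aromatic ring of carbon only while the fluorine gives way to a methoxy and a nitro group. Nothing available explains why the number falls this far.

On these data alone, the methoxy and nitro groups enter together, so their separate shares remain unknown. A phenyl ring carrying only one of them, or an amine in place of the nitro group, would be needed to show which part of the group matters.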